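Acyloxymethyl versus benzyl carbamates: buffer stability notes

The source may hold more compounds than are shown below. What is called first, only, known or untested is meant among the compounds shown, and "the series" means these compounds.

Measured compounds:
compound 1 `CC(C)C(=O)OCOC(=O)N1CCN(C(=O)c2nc(Nc3cc(C4CC4)[nH]n3)c3cc(Cl)ccc3n2)C[C@H]1C` — 93.5% in a physicochemical assay, read by HPLC, in phosphate buffer, with a stated time of 2 h, at pH 7.4; on this read-out higher numbers stand for a more stable compound and lower numbers for a less stable compound
compound 2 `C[C@@H]1CN(C(=O)c2nc(Nc3cc(C4CC4)[nH]n3)c3cc(Cl)ccc3n2)CCN1C(=O)OCc1ccccc1` — 97.7% in this assay

Compound 2 sits at the top of the two numbers, but compound 1 lies within the scatter of it: the step of a number 4.2 percentage points higher from compound 1 to compound 2 (within the scatter) is not a real difference. Compound 3 `C[C@@H]1CN(C(=O)c2nc(Nc3cc(C4CC4)[nH]n3)c3cc(Cl)ccc3n2)CCN1C(=O)OCOC(=O)C(C)(C)C` is to be measured next. It differs from compound 2 by ((tert-butyl)carbonyl)oxy in place of phenyl on a saturated chain carbon bound to an oxygen next to a carbonyl group. Among the measured compounds shown here, the only step that bears on this change is the one from compound 1 to compound 2, which swapped (isopropylcarbonyl)oxy for phenyl at the same place and gave a number 4.2 percentage points higher from compound 1 to compound 2 (within the scatter). Compound 3 reverses that kind of exchange with a ((tert-butyl)carbonyl)oxy group, so no step beyond the scatter is expected, and the estimated step is a number 3.7 percentage points lower from compound 2 to compound 3 (within the scatter). Compound 3 is therefore expected to give about 94%, within a range of 84% to 100%.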

Compound 3, percent of the compound remaining: 97.7%
Estimate against measurement, compound 3: 3.7 percentage points below, within the range that was stated.
By their numbers in this assay, from the lowest: compounds 1, 2 and 3 (each within the scatter of the next).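

In this assay, ((tert-butyl)carbonyl)oxy in place of phenyl on a saturated chain carbon bound to an oxygen next to a carbonyl group gives no change at the digits printed from compound 2 to compound 3 (within the scatter) and so adds a second exchange of this kind that stays inside the scatter. Methyl in place of hydrogen on a saturated chain carbon bound to a carbonyl carbon and two saturated chain carbons gives a number 4.2 percentage points higher from compound 1 to compound 3 (within the scatter) and shows that the two acyloxymethyl carbamates also cannot be separated in this assay. Nothing available bears on the reason for these results.

On these data alone, whether any group at this position can give a step beyond the scatter remains open. An amine or a carboxylic acid at the end of a longer chain in place of ((tert-butyl)carbonyl)oxy would test this in this assay.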